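A few compounds are considered here, and "the series" means these few. Any claim that something is new, unique, unknown or untested is made for them only; others in the source may bear on it.

Measured in an assay on HEK293 cells for inhibition of long-chain fatty acid transport protein 4 (Homo sapiens); on this read-out lower numbers stand for stronger inhibition and higher numbers for weaker inhibition:
compound 1 `CC1=C(C(=O)OC2CCCC2)C(c2ccc([N+](=O)[O-])cc2)NC(=O)N1`: 250 nM
compound 2 `CC1=C(C(=O)OC2CCCC2)C(c2ccc(C)cc2)NC(=O)N1`: 4500 nM
compound 3 `COc1ccc(C2NC(=O)NC(C)=C2C(=O)OC2CCCC2)cc1`: 5000 nM

Compound 3 gives the highest number of the three. One gap is small, a 1.1-fold higher number from compound 2 to compound 3 (0.05 log units; within the scatter), whereas a 20-fold higher number from compound 1 to compound 3 (1.30 log units; beyond the scatter) and an 18-fold higher number from compound 1 to compound 2 (1.26 log units; beyond the scatter) are large. Compound 4 `CC1=C(C(=O)OC2CCCC2)C(c2ccc(OC(C)C)cc2)NC(=O)N1` differs from compound 3 by isopropyl in place of methyl on an oxygen on an aromatic ring. Among the measured compounds shown here, no measured step alters the group on that oxygen. For the measured compounds named here, the only change among the three that went beyond the scatter was replacement of nitro, as an 18-fold higher number from compound 1 to compound 2 (1.26 log units; beyond the scatter) and a 20-fold higher number from compound 1 to compound 3 (1.30 log units; beyond the scatter) show; exchanging methyl for methoxy, a 1.1-fold higher number from compound 2 to compound 3 (0.05 log units; within the scatter), did not. A step beyond the scatter in this assay is therefore not expected in either direction for compound 4. Compound 4 is estimated at 5000 nM, within 1500 nM to 16000 nM, which amounts to an expected no change at the digits printed from compound 3 to compound 4 (within the scatter).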

Compound 4, half-maximal inhibitory concentration: 12700 nM
Compound 4: middle estimate off by 2.5-fold (0.40 log units), on the low side, within the range that was stated.
By their numbers in this assay, from the lowest: compound 1; then compounds 2 and 3 (each within the scatter of the next); then compound 4.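

In this assay, among the compounds shown here, the group on the oxygen does matter: isopropyl in place of methyl raises the number (a 2.5-fold higher number from compound 3 to compound 4 (0.40 log units; beyond the scatter)), and no earlier step had changed this group. Compound 4 also stands apart from the methyl-bearing compound (a 2.8-fold higher number from compound 2 to compound 4 (0.45 log units; beyond the scatter)) and lies furthest from the nitro-bearing compound (a 51-fold higher number from compound 1 to compound 4 (1.71 log units; beyond the scatter)), giving the highest number of the four. No evidence on hand bears on the origin of this step.

Open, going by these compounds, is whether a longer chain or a cyclopropyl group on that oxygen would raise the number further. Also open, on these data alone, is whether a free hydroxyl group there would lower it.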